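The source may report more compounds than this note shows. Statements on the series, on what has been measured and on what is new or still open speak of the compounds shown alone.

Compound 1 `O=C1C2CCCN2C(=O)CN1CN1CCN(c2cccc3c2CC=COO3)CC1`, compound 2 `C[C@@H]1CN(c2cccc3ccccc23)CCN1CN1CC(=O)N2CCC[C@H]2C1=O` and compound 3 `C[C@H]1CN(c2cccc3ccccc23)CCN1CN1CC(=O)N2CCC[C@H]2C1=O` are the measured members of the series. In an assay on membranes from Cerebral cortex for binding affinity to Adrenergic receptor alpha-1 (Rattus norvegicus) (on this read-out lower numbers stand for stronger inhibition and higher numbers for weaker inhibition), compound 1 gives > 1000 nM, which is a limit of the assay and not a number. In this assay compound 2 gives > 1000 nM, likewise a limit. In this assay compound 3 gives > 1000 nM, again a limit. Compound 3 thus stands where the other two stand, at the limit, and no order among the three can be read. For the measured compounds named here, the one step between close neighbours, a step that the two limits leave unreadable from compound 2 to compound 3, cannot be sized because of the limit of > 1000 nM in this assay, at which 3 of the 3 values shown sit; that the pair differs only as the fact that compounds 2 and 3 differ only in the configuration as drawn states adds nothing readable about size.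

Compound 4 `C[C@@H]1CN(c2cccc3ccccc23)CCN1CN1CC(=O)N2CCC[C@@H]2C1=O` follows compound 3 by the two compounds have the same atoms and bonds and differ only in configuration as drawn: 2 of 2 stereo elements differ (all stereocentres are inverted: mirror images); a stereocentre at a saturated ring carbon is drawn S in compound 3 and R in compound 4; a stereocentre at a saturated ring carbon is drawn S in compound 3 and R in compound 4. Going by the values given here, the only measured step that bears on it, a step that the two limits leave unreadable from compound 2 to compound 3, gives no size, so nothing beyond the scatter can be foreseen in this assay. The step that the limit leaves unreadable from compound 3 to compound 4 is expected to be unreadable in the same way. Compound 4 is estimated at 3000 nM, within 800 nM to 15000 nM, most likely reported as a limit only.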

Compound 4, inhibition constant: > 1000 nM
Compound 4: no number, only a limit (the forecaster's own chance of this, stated with the estimate: 75%); the middle value does not contradict the limit.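

In this assay compound 4 gives > 1000 nM, a limit of the assay and not a number, so its steps to compound 2 and compound 3 cannot be read. The compounds shown leave open whether configuration at either stereocentre affects binding affinity in this assay.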